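A few compounds are considered here, and "the series" means these few. Any claim that something is new, unique, unknown or untested is made for them only; others in the source may bear on it.

Three compounds share one core and differ only in the aromatic ring attached through the (4-chlorobenzyl)sulfanyl-type side group. In a functional assay on the whole organism (artery, strain albino) with Rattus norvegicus as the target, with a stated time of 300 min, at a dose of 10 mg/kg by the oral route (on this read-out lower numbers stand for less inhibition and higher numbers for more inhibition at the one dose given (going by the name of the read-out)), compound 1 `CC1=C(C(=O)Nc2ccc([N+](=O)[O-])cc2)C(c2ccc(Br)cc2)N=C(SCc2cccc(Cl)c2)N1` gives 9.2%. Compound 2 `CC1=C(C(=O)Nc2ccc([N+](=O)[O-])cc2)C(c2ccc(Br)cc2)N=C(SCc2ccc(Cl)cc2)N1` gives 37.9%, and compound 3 `CC1=C(C(=O)Nc2ccc([N+](=O)[O-])cc2)C(c2ccc(Br)cc2)N=C(SCc2ccc(F)cc2)N1` gives 34.4%. Compound 2 holds the top number of the three, but compound 3 lies within the scatter of it, so the two cannot be told apart; the step of a number 3.5 percentage points lower from compound 2 to compound 3 (within the scatter) stays inside the noise. Only compound 1 is clearly set apart, by a number 28.7 percentage points higher from compound 1 to compound 2 (beyond the scatter) and by a number 25.2 percentage points higher from compound 1 to compound 3 (beyond the scatter).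

Compound 4 `CC1=C(C(=O)Nc2ccc([N+](=O)[O-])cc2)C(c2cccc([N+](=O)[O-])c2)N=C(SCc2ccc(Cl)cc2)N1` changes a different part of the molecule: 3-nitrophenyl in place of 4-bromophenyl on a saturated ring carbon. Among the measured compounds shown here, none of the measured steps touches that saturated ring carbon, so none of them bears directly on this change, and the data give no ground to expect a shift beyond the scatter in this assay. Compound 4 is therefore expected to stay near compound 2, at an estimated 35%, within 12% to 58%. The expected step is a number 2.9 percentage points lower from compound 2 to compound 4 (within the scatter).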

Compound 4, a percentage reported as inhibition, in the whole organism at one dose (the size of the read-out at that dose, not a potency): 24.1%
The estimate for compound 4 lay 10.9 percentage points above the measured number; low and high end bracket the measured number.
By their numbers in this assay, from the lowest: compound 1; then compound 4; then compounds 3 and 2 (each within the scatter of the next).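

The saturated ring carbon is also a place where a change counts: in this assay, placing 3-nitrophenyl there instead of 4-bromophenyl gives a number 13.8 percentage points lower from compound 2 to compound 4 (beyond the scatter). So the number responds not only to the ring on the sulfur side group, the only part varied among the earlier compounds, but also to this second part of the molecule. This single swap replaces bromine with a nitro group and also changes the numbered ring position of that group, and no measurement here explains the shift or separates those two changes.

As far as these compounds go, it remains open how a plain phenyl, or a phenyl carrying an amine or a carboxylic acid, would behave at this carbon. Also open, from the compounds shown here alone, is whether this step would be the same size with the side group of compound 1 or compound 3 in place.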